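Adding a methyl to the core of compound 1

The compounds below may be only part of what the source reports. "The series", "measured", "known", "first", "only" and "open" are said of these compounds alone.

Measured so far in a functional assay on PANC-1 cells (Homo sapiens) for cytotoxicity, read by MTT assay, with a stated time of 72 h (on this read-out higher numbers stand for weaker inhibition and lower numbers for stronger inhibition), for two compounds:
compound 1 `CN1CCN(c2ccc(NC3=CC(=O)c4ncncc4C3=O)cc2)CC1` gives 340 nM
compound 2 `CCc1ccc(-c2ccc(NC3=CC(=O)c4ncncc4C3=O)cc2)cc1` gives 2300 nM

Compound 1 holds the lower of the two numbers in this assay at 340 nM and serves as the reference here. Compound 3 `CC1=C(Nc2ccc(N3CCN(C)CC3)cc2)C(=O)c2cncnc2C1=O` differs from it by methyl in place of hydrogen on a double-bonded ring carbon in one place: methyl in place of hydrogen on a double-bonded ring carbon. Within the data shown here, the only measured step is a 6.8-fold higher number from compound 1 to compound 2 (0.83 log units; beyond the scatter) and, lying elsewhere in the molecule, bears on this change only loosely. Among the measured compounds shown here, no measured step touches this place, so only a modest rise in the number is expected. The expected size is a 1.6-fold higher number from compound 1 to compound 3 (0.21 log units; within the scatter) on this estimate. The estimate for compound 3 is 550 nM with a range from 180 nM to 1700 nM expected.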

Compound 3, half-maximal inhibitory concentration: 380 nM
Compound 3: the middle estimate sits 1.4-fold (0.16 log units) above what was measured, and the stated range covers the measured number.
By their numbers in this assay, from the lowest: compounds 1 and 3 (each within the scatter of the next); then compound 2.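

In this assay methyl in place of hydrogen on the double-bonded ring carbon gives a 1.1-fold higher number from compound 1 to compound 3 (0.05 log units; within the scatter) and so this carbon of the shared core carries a methyl with no shift beyond the scatter. Among these compounds, this is the first reading at this place, as the earlier step concerned another part of the molecule. Nothing measured on these compounds gives a reason for this result.

On these data alone, whether an ethyl group, an amine or a carboxylic acid at this carbon would fare the same stays open. Also open, as far as these compounds go, is whether methyl here would read alike with the 4-ethylphenyl group of compound 2.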